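The source may report more compounds than this note shows. Statements on the series, on what has been measured and on what is new or still open speak of the compounds shown alone.

Measured compounds:
Compound 1 `CC(C)NCc1ccc(-c2c3ncn(CC4(O)CCN(Cc5ccc(-c6ccco6)cc5Cl)CC4)c(=O)c3nn2C)cc1` gives 29.1 nM in an assay on isolated protein for inhibition of ubiquitin carboxyl-terminal hydrolase 7 (Homo sapiens), with stated times of 30 min and 2 h; on this read-out lower numbers stand for stronger inhibition and higher numbers for weaker inhibition.
Compound 2 `Cn1nc2c(=O)n(CC3(O)CCN(Cc4ccc(-c5ccco5)cc4Cl)CC3)cnc2c1-c1ccc(C(F)(F)F)cc1` gives 530 nM in this assay.
Compound 3 `Cn1nc2c(=O)n(CC3(O)CCN(Cc4ccc(-c5ccco5)cc4Cl)CC3)cnc2c1-c1ccc(F)cc1` gives 64.5 nM in this assay.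

All three share the same core and differ only in one group on the outer benzene ring. Compound 3 stands second highest of the three numbers: compound 1 lies nearest, with a 2.2-fold higher number from compound 1 to compound 3 (0.35 log units; beyond the scatter), and compound 2 lies furthest, with an 8.2-fold lower number from compound 2 to compound 3 (0.91 log units; beyond the scatter). The step from compound 1 to compound 2 was the largest of all, an 18-fold higher number from compound 1 to compound 2 (1.26 log units; beyond the scatter).

Compound 4 `CCCNCc1ccc(-c2c3ncn(CC4(O)CCN(Cc5ccc(-c6ccco6)cc5Cl)CC4)c(=O)c3nn2C)cc1` has not yet been measured. Compared with compound 3 the change is (propylamino)methyl in place of fluoro on an aromatic carbon. Within the data shown here, the step that bears most on this is the one from compound 1 to compound 3, since the group entering in compound 4 is a close relative of the (isopropylamino)methyl group of compound 1; that step was a 2.2-fold higher number from compound 1 to compound 3 (0.35 log units; beyond the scatter). Reversing it, the number for compound 4 is expected to fall by a modest step, a 2.2-fold lower number from compound 3 to compound 4 (0.33 log units; beyond the scatter), though no measured pair shows this exact pair of groups. Compound 4 is therefore estimated at 30 nM, within a range from 12 nM to 80 nM.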

Compound 4, half-maximal inhibitory concentration: 43.9 nM
The estimate for compound 4 lay 1.5-fold (0.17 log units) below the measured number; low and high end bracket the measured number.
By their numbers in this assay, from the lowest: compounds 1, 4 and 3 (each within the scatter of the next, the first and the last beyond it); then compound 2.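

In this assay, propyl and isopropyl on the amine nitrogen cannot be told apart at this position, with a 1.5-fold higher number from compound 1 to compound 4 (0.18 log units; within the scatter). Compound 4 also cannot be separated from the small fluoro group, with a 1.5-fold lower number from compound 3 to compound 4 (0.17 log units; within the scatter), so having the amine side chain on this aromatic carbon does not by itself give a clear gain over fluoro, even though compound 1 did stand beyond the scatter from compound 3; only trifluoromethyl remains clearly apart, with a 12-fold lower number from compound 2 to compound 4 (1.08 log units; beyond the scatter). No measurement shown here explains why these groups behave as they do.

On these data alone, what remains open is how much the amine nitrogen itself contributes, which a group such as hydroxymethyl or methoxymethyl in the same place could test. Also open, as far as these compounds go, is how far the chain on the nitrogen can change, for instance to a longer butyl chain or a cyclopropyl ring, before the number in this assay shifts beyond the scatter.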